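Removing a Methoxy Group in Two Related Series

The source may report more compounds than this note shows. Statements on the series, on what has been measured and on what is new or still open speak of the compounds shown alone.

Measured so far in a functional assay on THP-1 cells (Homo sapiens) for inhibition, read by sulforhodamine B assay, with a stated time of 48 h, tested at 50 uM; a higher number here means more inhibition of growth at the concentration tested, a lower number less inhibition of growth:
compound 1, `COc1ccc(/C=C/C(=O)/C=C/c2ccc(OCc3cn(CCCCOc4cc(=O)oc5ccccc45)nn3)c(OC)c2)cc1OC`, gives 59%
compound 2, `COc1ccccc1/C=C/C(=O)/C=C/c1ccc(OCc2cn(CCCCCOc3cc(=O)oc4ccccc34)nn2)c(OC)c1`, gives 37%
compound 3, `COc1cc(/C=C/C(=O)/C=C/c2cc(OC)c(OC)c(OC)c2)ccc1OCc1cn(CCCCOc2cc(=O)oc3ccccc23)nn1`, gives 65%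

Compound 2 stands lowest of the three. How its core differs from the core of compound 3 is not broken down here. From compound 3 to compound 1 the change is hydrogen in place of methoxy on an aromatic carbon, and the step is a number 6 percentage points lower from compound 3 to compound 1 (within the scatter). Compound 4, `COc1cc(/C=C/C(=O)/C=C/c2ccccc2)ccc1OCc1cn(CCCCCOc2cc(=O)oc3ccccc23)nn1`, is not yet measured; it arises from compound 2 by hydrogen in place of methoxy on an aromatic carbon. This is the same kind of change, yet the surroundings differ: in compound 3 the methoxy leaves a carbon ortho to a methoxy group, meta to a large group and meta to a methoxy group, whereas in compound 2 it leaves a carbon ortho to a large group. Because a number 6 percentage points lower from compound 3 to compound 1 (within the scatter) lay within the scatter, the step from compound 2 to compound 4 is expected to be small, a number 2 percentage points lower from compound 2 to compound 4 (within the scatter). Compound 4 is therefore estimated at 35%, between 20% and 52%.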

Compound 4, percent growth inhibition at one concentration: 26%
Beside the measured number, compound 4's estimate is 9 percentage points above it, and the stated range covers the measured number.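

In this assay, hydrogen in place of methoxy on an aromatic carbon gave a number 11 percentage points lower from compound 2 to compound 4 (beyond the scatter). Set beside the earlier step, the change carries across the two cores with no difference in size that can be told apart: the same change on two cores in this assay, a number 6 percentage points lower (within the scatter) from compound 3 to compound 1 and a number 11 percentage points lower (beyond the scatter) from compound 2 to compound 4, 5 percentage points apart, within the scatter of two such steps. Among these compounds, this rests on one pair per core, with the methoxy leaving different surroundings in each, so it does not show that the step would keep its size on a further core, nor why only one of the two steps lies beyond the scatter.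

The compounds shown leave open what a hydroxyl group, a fluorine atom or an amine would do in place of the methoxy. They also leave open whether the step holds on a core with a longer chain.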